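Lengthening the chain of a hydroxyphenyl ketone by one methyl

The source may hold more compounds than are shown below. What is called first, only, known or untested is meant among the compounds shown, and "the series" means these compounds.

For the measured compounds named here, compound 2 `CCCCCCC(=O)c1ccc(O)cc1` stands highest of the two numbers so far in an assay on isolated protein for inhibition of 17-beta-hydroxysteroid dehydrogenase type 3 (Homo sapiens), tested at 100 uM (a higher number here means more inhibition at the concentration tested (going by the name of the read-out), a lower number less inhibition), where compound 2 gives 80.3%. Its nearest neighbour, compound 1 `CCCCCC(=O)c1ccc(O)cc1`, gives 76.4% in this assay, and the gap between the two lies within the scatter. Compound 3 `CCCCCCCC(=O)c1ccc(O)cc1` has not yet been measured. It differs from compound 2 in one place: methyl in place of hydrogen on a saturated chain carbon, six bonds along the chain from a carbonyl carbon. Going by the values given here, the only measured step that bears on this change is a number 3.9 percentage points higher from compound 1 to compound 2 (within the scatter), the same kind of change placed five bonds along the chain from a carbonyl carbon rather than six, and that step stayed within the scatter. On that basis the step to compound 3 is expected to be a number 1.7 percentage points higher from compound 2 to compound 3 (within the scatter), with no direction beyond the scatter. Compound 3 is therefore estimated at 82% in this assay, expected to lie between 70% and 92%.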

Compound 3, a percentage reported as inhibition, at one concentration (the size of the read-out at that concentration, not a potency): 82.6%
For compound 3 the middle estimate is 0.6 percentage points below the measured one, and the stated range covers the measured number.
By their numbers in this assay, from the lowest: compounds 1, 2 and 3 (each within the scatter of the next).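

In this assay, methyl at the carbon six bonds along the chain from a carbonyl carbon gives a number 2.3 percentage points higher from compound 2 to compound 3 (within the scatter) and so brings no change that can be told from the scatter. Ethyl in place of hydrogen on the saturated chain carbon five bonds along from the carbonyl carbon gives a number 6.2 percentage points higher from compound 1 to compound 3 (within the scatter) and so stays within the scatter as well, which means that even the larger change across these three compounds shows no reliable effect of chain length. Nothing available explains why the numbers stay so close.

Going by these compounds, what a longer chain would do in this assay remains open. So does the effect of an amine or a carboxylic acid on the chain, since all three compounds carry only a plain saturated chain.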